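The source may hold more compounds than are shown below. What is called first, only, known or untested is meant among the compounds shown, and "the series" means these compounds.

Working notes on the series, cytotoxicity. Compound 1 `O=[N+]([O-])c1cn2c(n1)OC[C@@H](OCc1cc(-c3ccc(F)cc3)no1)C2` carries fluoro on the aryl ring. In an ADME assay on Vero cells (Chlorocebus sabaeus) for cytotoxicity, with a stated time of 72 h (a higher number here means a weaker inhibitor, a lower number a stronger inhibitor), compound 1 gives > 128000 nM, which is a limit of the assay and not a number. Compound 2 `O=[N+]([O-])c1cn2c(n1)OC[C@@H](OCc1cc(-c3ccc(OC(F)(F)F)cc3)no1)C2` arises from compound 1 by trifluoromethoxy in place of fluoro on an aromatic carbon. In this assay compound 2 gives > 128000 nM, again a limit. The step that the two limits leave unreadable from compound 1 to compound 2 therefore cannot be read, which rests on (the limit of > 128000 nM in this assay, at which 3 of the 3 values shown sit). Compound 3 `O=[N+]([O-])c1cn2c(n1)OC[C@@H](OCc1cnn(-c3ccc(F)cc3)n1)C2` has another core; the difference between the two cores is not broken down here. In this assay compound 3 gives > 128000 nM, also a limit. Compound 4 `O=[N+]([O-])c1cn2c(n1)OC[C@@H](OCc1cnn(-c3ccc(OC(F)(F)F)cc3)n1)C2` is not yet measured and differs from compound 3 by trifluoromethoxy in place of fluoro on an aromatic carbon, the same change as from compound 1 to compound 2, with the place described identically. Within the data shown here, because the earlier step that the two limits leave unreadable from compound 1 to compound 2 is unreadable and every value so far sits at the limit of > 128000 nM in this assay, at which 3 of the 3 values shown sit, compound 4 is expected to show a step that the limit leaves unreadable from compound 3 to compound 4 and an estimate of 200000 nM, between 100000 nM and 500000 nM, most likely again reported only as a limit.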

Compound 4, half-maximal inhibitory concentration: > 128000 nM
Compound 4 ended at the assay's limit (the forecaster's own chance of this, stated with the estimate: 85%); the middle value lies beyond the limit too.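

The step from compound 3 to compound 4 cannot be read, because both values are limits of the assay and not numbers: the limit of > 128000 nM in this assay, at which 4 of the 4 values shown sit.

The compounds shown leave open whether trifluoromethoxy in place of fluoro alters cytotoxicity at all.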